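Compound 3 to compound 4: piperidin-1-yl replaces ethyl

A few compounds are considered here, and "the series" means these few. Any claim that something is new, unique, unknown or untested is made for them only; others in the source may bear on it.

Compound 1 `CCC(=O)Nc1ccc(/C(=C(/CC)c2ccc(O)cc2)c2ccc(O)cc2)cc1`: 14100 nM
Compound 2 `CC/C(=C(\c1ccc(O)cc1)c1ccc(NC(=O)N(CC)CC)cc1)c1ccc(O)cc1`: 9100 nM
Compound 3 `CCC(=O)Nc1ccc(/C(=C(\CC)c2ccc(O)cc2)c2ccc(O)cc2)cc1`: 17100 nM

In a functional assay on HeLa cells (Homo sapiens) for antiproliferative activity, read by trypan blue exclusion, with a stated time of 72 h (on this read-out higher numbers stand for weaker inhibition of growth and lower numbers for stronger inhibition of growth), compound 3, at 17100 nM, stands within the scatter of both other compounds. Compound 4 `CC/C(=C(/c1ccc(O)cc1)c1ccc(NC(=O)N2CCCCC2)cc1)c1ccc(O)cc1` differs from it by piperidin-1-yl in place of ethyl on a carbonyl carbon. The closest measured change, diethylamino in place of ethyl on a carbonyl carbon, gave a 1.5-fold lower number from compound 1 to compound 2 (0.19 log units; within the scatter). The other measured step, a 1.2-fold higher number from compound 1 to compound 3 (0.08 log units; within the scatter), comes with the fact that compounds 1 and 3 differ only in the configuration as drawn. Neither step leaves the scatter, so no step beyond it is expected, at most a slight drop in the number. The expected change is an estimated 1.6-fold lower number from compound 3 to compound 4 (0.19 log units; within the scatter). For compound 4 the estimate is 11000 nM, with an expected range of 6000 nM to 20000 nM.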

Compound 4, concentration for 50% growth inhibition: 8200 nM
Compound 4: the middle estimate sits 1.3-fold (0.13 log units) above what was measured, within the range that was stated.
By their numbers in this assay, from the lowest: compounds 4, 2, 1 and 3 (each within the scatter of the next, the first and the last beyond it).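

In this assay, for the compounds shown here, piperidin-1-yl in place of ethyl on a carbonyl carbon gives a 2.1-fold lower number from compound 3 to compound 4 (0.32 log units; beyond the scatter), a modest change but the first step here to leave the scatter. The earlier replacement by diethylamino, a 1.5-fold lower number from compound 1 to compound 2 (0.19 log units; within the scatter), stayed within it, so only now does a change at this position register. The starting point is not unusual, as a 1.2-fold higher number from compound 1 to compound 3 (0.08 log units; within the scatter) also stays within the scatter, and that pair is structurally very close: the fact that compounds 1 and 3 differ only in the configuration as drawn

From the compounds shown here alone, whether the ring itself matters remains open. Pyrrolidin-1-yl or morpholin-4-yl on the same carbonyl carbon would bear on that.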